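Adding a Second Chlorine to a Fused Core

The source may report more compounds than this note shows. Statements on the series, on what has been measured and on what is new or still open speak of the compounds shown alone.

Of the compounds shown here, three have been tested in a functional assay on EKVX cells (Homo sapiens) for cytotoxicity, read by sulforhodamine B assay, with a stated time of 48 h; a higher number here means a weaker inhibitor of growth, a lower number a stronger inhibitor of growth. Compound 1 `ClCc1ccccc1Cn1cnc2c(Cl)nc(Cl)nc21` carries two chloro groups on its fused core, and in this assay compound 1 gives 3230 nM. Compound 2 `ClCc1ccccc1Cn1cnc2c(Cl)ncnc21` carries one chloro group; in this assay compound 2 gives 11000 nM. The step of a 3.4-fold lower number from compound 2 to compound 1 (0.53 log units; beyond the scatter) is the change (chloro in place of hydrogen on an aromatic carbon).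

Compound 3 `ClCc1ccccc1Cn1cnc2ncnc(Cl)c21` is built from the same atoms as compound 2, joined differently; the difference between the two cores is not broken down here. In this assay compound 3 gives 17800 nM, and the gap between compound 3 and compound 2 is within the scatter.

Compound 4 `ClCc1ccccc1Cn1cnc2nc(Cl)nc(Cl)c21` has not been measured. It differs from compound 3 by chloro in place of hydrogen on an aromatic carbon, and the place where the chloro group enters is described in the same words as for the change from compound 2 to compound 1, so this is the same change on a different core. On that basis compound 4 is expected to show a step of about a 3.2-fold lower number from compound 3 to compound 4 (0.51 log units; beyond the scatter), echoing the earlier step of a 3.4-fold lower number from compound 2 to compound 1 (0.53 log units; beyond the scatter). The estimate for compound 4 in this assay is 5500 nM, with a likely range from 2500 nM to 12000 nM.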

Compound 4, concentration for total growth inhibition: 3230 nM
Estimate against measurement, compound 4: 1.7-fold (0.23 log units) above; the measured number falls inside the stated range.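

In this assay the chloro group that takes the place of a hydrogen on an aromatic carbon gives a 5.5-fold lower number from compound 3 to compound 4 (0.74 log units; beyond the scatter) on this second core, the same direction as on the first. The two steps can be read as one repeated effect, since their sizes do not differ by more than repeated measurements would scatter: the same change on two cores in this assay, a 3.4-fold lower number (0.53 log units; beyond the scatter) from compound 2 to compound 1 and a 5.5-fold lower number (0.74 log units; beyond the scatter) from compound 3 to compound 4, 1.6-fold (0.21 log units) apart, within the scatter of two such steps. This shows that the change carried over between these two closely related cores in one cell line, but two cores are a small sample: it does not show that the step would hold on any other core, and it does not explain why the number falls.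

Whether the lower number needs chlorine in particular stays open, as the compounds shown carry only hydrogen or a chloro group on that carbon. An amine or a methoxy group at the same place would show whether other groups bring a similar step.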